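Carboxyphenoxy in Place of Furan on a Shared Core

The source may report more compounds than this note shows. Statements on the series, on what has been measured and on what is new or still open speak of the compounds shown alone.

Measured compounds:
compound 1 `Cc1ccccc1-n1nc(C)c2c1NC(=O)[C@H](C)S[C@@H]2c1ccc(-c2ccoc2)cc1`: 3500 nM
compound 2 `COc1cc([C@H]2S[C@@H](C)C(=O)Nc3c2c(C)nn3-c2ccccc2C)ccc1Oc1ccccc1`: 1900 nM

Of the compounds shown here, two have been tested so far in an assay on isolated protein for agonist activity at Bile acid receptor (Homo sapiens), read by AlphaScreen, with a stated time of 30 min; a higher number here means that more compound is needed for the effect, a lower number that less compound is needed. Compound 1 `Cc1ccccc1-n1nc(C)c2c1NC(=O)[C@H](C)S[C@@H]2c1ccc(-c2ccoc2)cc1` gives 3500 nM, and compound 2 `COc1cc([C@H]2S[C@@H](C)C(=O)Nc3c2c(C)nn3-c2ccccc2C)ccc1Oc1ccccc1` gives 1900 nM. Compound 1 shows the higher of the two numbers, yet its gap to compound 2 lies within the usual scatter of this assay, so the two cannot be told apart on these data.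

Compound 3 `Cc1ccccc1-n1nc(C)c2c1NC(=O)[C@H](C)S[C@@H]2c1ccc(Oc2ccc(C(=O)O)cc2)cc1` is not yet measured. It differs from compound 1 in a single place: 4-carboxyphenoxy in place of furan-3-yl on an aromatic carbon. Within the data shown here, no step between measured compounds is available, so the size of this change has to be estimated rather than read off. The step of a 4.4-fold lower number from compound 1 to compound 3 (0.64 log units; beyond the scatter) is expected to be moderate, toward a lower number, and somewhat beyond the scatter. Compound 3 is estimated at 800 nM, with a likely range from 200 nM to 4000 nM.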

Compound 3, half-maximal effective concentration: "not active" (no number reported)
The entry for compound 3 holds no number; no gap can be computed for the estimate.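

Among these compounds, compound 3 is reported as "not active" in this assay, without a number, so no step from compound 1 to compound 3 can be read. Nothing shown explains this result. The compounds shown leave open which part of 4-carboxyphenoxy goes with this outcome.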